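The compounds below may be only part of what the source reports. "The series", "measured", "known", "first", "only" and "open" are said of these compounds alone.

Of the compounds shown here, three built on one shared core have been tested in a functional assay on MDA-MB-231 cells (Homo sapiens) for cytotoxicity, read by sulforhodamine B assay, with a stated time of 48 h; on this read-out higher numbers stand for weaker inhibition of growth and lower numbers for stronger inhibition of growth. Compound 1 `Cc1ccc(-c2ccc(C)n2-c2ccc(-c3nc4ccccc4s3)cc2)cc1` gives 4400 nM, compound 2 `Cc1ccc(-c2ccc(F)cc2)n1-c1ccc(-c2nc3ccccc3s2)cc1` gives 4340 nM, and compound 3 `COc1ccc(-c2ccc(C)n2-c2ccc(-c3nc4ccccc4s3)cc2)cc1` gives 3990 nM. Compound 3 sits within the scatter of both others, since the steps of a 1.1-fold lower number from compound 1 to compound 3 (0.04 log units; within the scatter) and a 1.1-fold lower number from compound 2 to compound 3 (0.04 log units; within the scatter) are small. Compound 4 `Cc1ccc(-c2ccc([N+](=O)[O-])cc2)n1-c1ccc(-c2nc3ccccc3s2)cc1` differs from compound 3 by nitro in place of methoxy on an aromatic carbon. Among the compounds with values here, no measured step involves a nitro group; what bears on the change is only that the exchanges of methyl, fluoro and methoxy on that aromatic carbon, including a 1.0-fold lower number from compound 1 to compound 2 (0.01 log units; within the scatter), all stayed within the scatter. The expected step is therefore a 1.0-fold higher number from compound 3 to compound 4 (0.01 log units; within the scatter), nothing beyond the scatter. The estimate for compound 4 in this assay is 4100 nM, with a range from 2000 nM to 8500 nM.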

Compound 4, concentration for 50% growth inhibition: 3900 nM
Estimate against measurement, compound 4: 1.1-fold (0.02 log units) above; measured number inside the range.
By their numbers in this assay, from the lowest: compounds 4, 3, 2 and 1 (each within the scatter of the next).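

Nitro now joins methyl, fluoro and methoxy on this aromatic carbon, para to a large group, and every step to it stays within the scatter: a 1.0-fold lower number from compound 3 to compound 4 (0.01 log units; within the scatter), a 1.1-fold lower number from compound 2 to compound 4 (0.05 log units; within the scatter) and a 1.1-fold lower number from compound 1 to compound 4 (0.05 log units; within the scatter). Across these four compounds, then, exchanging the group at this position leaves growth inhibition unchanged within the scatter. Nothing available here gives a reason for this. From the compounds shown here alone, it remains open whether an amine, a carboxylic acid or a longer chain at this position would also stay within the scatter. Changes elsewhere on the shared core also remain untested by these compounds.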